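The source may hold more compounds than are shown below. What is called first, only, known or untested is meant among the compounds shown, and "the series" means these compounds.

In an in vitro ADME assay on microsomes from liver (Homo sapiens) for metabolic stability (a lower number here means slower removal, a higher number faster removal of the compound), compound 1 `CS(=O)(=O)N[C@H]1CC[C@H](c2n[nH]cc2-c2ccnc(NC3CCCC3)n2)CC1` gives 0.011 mL/min/kg while compound 2 `Clc1ccc(-c2n[nH]cc2-c2ccnc(NC3CC3)n2)cc1` gives 0.096 mL/min/kg and so stands the higher of the two, beyond the scatter. Compound 3 `C[C@H](CC(=O)O)Nc1nccc(-c2c[nH]nc2-c2ccc(Cl)cc2)n1` differs from compound 2 by 1-(carboxymethyl)ethyl in place of cyclopropyl on a nitrogen on an aromatic ring, counted as 1-(carboxymethyl)ethyl in place of cyclopropyl on a nitrogen on an aromatic ring in full. Among the compounds with values here, no measured pair shows this change, so only a modest fall is expected, possibly within the scatter. The expected move is a 1.9-fold lower number from compound 2 to compound 3 (0.28 log units; within the scatter) as a rough estimate. For compound 3 the estimated clearance is 0.05 mL/min/kg with a range from 0.012 mL/min/kg to 0.2 mL/min/kg as its likely span.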

Compound 3, clearance: < 0.006 mL/min/kg
Compound 3: a limit, no number; the forecaster's own chance of this, stated with the estimate: 10%; middle value at least 8.3-fold (0.92 log units) away from the limit.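

On a nitrogen on an aromatic ring, 1-(carboxymethyl)ethyl in place of cyclopropyl gives in this assay an at least 16-fold lower number from compound 2 to compound 3 (1.20 log units; beyond the scatter), the first step read at this position and one beyond the scatter. On these data alone, compound 3 carries a limit and not a number, so the full size of this step stays unknown: the limit of < 0.006 mL/min/kg in this assay, at which 1 of the 3 values shown sits.

As far as these compounds go, whether the open chain or its carboxylic acid carries the step remains open. So does whether an amide or a primary alcohol at the chain end, or a longer chain, would give a step of like size.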